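The compounds below may be only part of what the source reports. "The series", "measured", "known", "first", "only" and "open" are said of these compounds alone.

Working notes on the series. In a functional assay on cardiac atrium for antagonist activity at histamine H2 receptor (Cavia porcellus) (on this read-out higher numbers stand for higher potency (the scale is a negative logarithm) and lower numbers for lower potency), compound 2 `N#CN/C(=N\CCNc1ccc(N=[N+]=[N-])cc1[N+](=O)[O-])NCCCOc1cccc(CN2CCCCC2)c1` gives 7.39, the lowest of the three numbers at hand. Compound 1 `N#CN/C(=N\CCOC(=O)c1ccccc1)NCCCOc1cccc(CN2CCCCC2)c1` gives 7.64 in this assay, a number that stays within the usual scatter of the value for compound 2, so no order between these two is claimed. Compound 3 `N#CN/C(=N\CCCNc1ccccc1[N+](=O)[O-])NCCCCOc1cccc(CN2CCCCC2)c1` gives 7.85 in this assay, which lies beyond the scatter above compound 2; of the three, only compound 3 is clearly separated from compound 2. For the measured compounds named here, no pair among the measured compounds differs in a single place, so no measured step bears directly on the change considered here. Compound 4 `N#CN/C(=N\CCNC(=O)c1ccc(N=[N+]=[N-])cc1)NCCCOc1cccc(CN2CCCCC2)c1` has not yet been measured. Relative to compound 2 it carries (4-azidophenyl)carbonyl in place of 4-azido-2-nitrophenyl on an amine nitrogen, the shared core being kept. Going by the values given here, with no comparable measured step to lean on, the change is expected to move the number only a little, with no direction beyond the scatter favoured. For compound 4 the estimate is 7.5, with a range of 7 to 8, an expected step of a number 0.11 log units higher from compound 2 to compound 4 (within the scatter).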

Compound 4, negative logarithm of the antagonist equilibrium constant: 7.9
For compound 4 the middle estimate is 0.40 log units below the measured one; the range from low to high includes it.
By their numbers in this assay, from the lowest: compounds 2, 1, 3 and 4 (each within the scatter of the next, the first and the last beyond it).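

In this assay, for the compounds shown here, (4-azidophenyl)carbonyl in place of 4-azido-2-nitrophenyl on an amine nitrogen gives a number 0.51 log units higher from compound 2 to compound 4 (beyond the scatter), the first measured step at this position and a modest one, so the position does respond to the group it carries. The other new comparison, ((4-azidophenyl)carbonyl)amino in place of benzoyloxy on the saturated chain carbon, gives a number 0.26 log units higher from compound 1 to compound 4 (within the scatter), so no order is claimed for that change. Nothing available on these compounds accounts for the size or direction of either step.

The first change removes the nitro group and introduces the carbonyl in a single step, so the compounds shown cannot separate the two contributions. Also open, on these data alone, is what a plain benzoyl or a (4-aminophenyl)carbonyl on the same nitrogen would give, which would show whether the azido group matters here.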